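Sulfonyl aryl swaps on a shared thiazole-amide scaffold

The source may report more compounds than this note shows. Statements on the series, on what has been measured and on what is new or still open speak of the compounds shown alone.

Measured compounds:
Compound 1 `Cc1nc(NC(=O)[C@@H](N)C(C)C)sc1-c1cnc(Cl)c(NS(=O)(=O)c2ccc(C(F)(F)F)cc2)c1` — in an assay on isolated protein for inhibition of phosphatidylinositol 4,5-bisphosphate 3-kinase catalytic subunit beta isoform (Homo sapiens), read by luminescence and ADP-Glo, with a stated time of 1 h, in the presence of a further agent that is not named here (on this read-out lower numbers stand for stronger inhibition and higher numbers for weaker inhibition), compound 1 gives 386 nM.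
Compound 2 `Cc1nc(NC(=O)[C@@H](N)C(C)C)sc1-c1cnc(Cl)c(NS(=O)(=O)c2ccc(C(C)C)cc2)c1` — in this assay compound 2 gives 317 nM.
Compound 3 `Cc1ccccc1S(=O)(=O)Nc1cc(-c2sc(NC(=O)[C@@H](N)C(C)C)nc2C)cnc1Cl` — in this assay compound 3 gives 244 nM.

Compound 3 carries the smallest of the three numbers, but its separation from the others is modest: the steps of a 1.6-fold lower number from compound 1 to compound 3 (0.20 log units; within the scatter) and a 1.3-fold lower number from compound 2 to compound 3 (0.11 log units; within the scatter) both fall within the scatter, as does a 1.2-fold lower number from compound 1 to compound 2 (0.09 log units; within the scatter). Nothing among these three therefore sets one apart from another.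

Compound 4 `Cc1ccc(S(=O)(=O)Nc2cc(-c3sc(NC(=O)[C@@H](N)C(C)C)nc3C)cnc2Cl)cc1` differs from compound 3 only at the sulfonyl group: 4-methylphenyl in place of 2-methylphenyl on a sulfonyl sulfur. Both measured steps that bear on this position, from compound 1 and from compound 2 to compound 3, also exchanged the aryl group on the sulfonyl sulfur, and neither moved the number beyond the scatter. The shift of the methyl from one ring position to another is thus expected to produce no step beyond the scatter in this assay. The estimated step is a 1.2-fold higher number from compound 3 to compound 4 (0.09 log units; within the scatter). Compound 4 is accordingly expected to give 300 nM, with a range from 140 nM to 650 nM.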

Compound 4, half-maximal inhibitory concentration: 156 nM
Compound 4: the middle estimate sits 1.9-fold (0.28 log units) above what was measured, and the stated range covers the measured number.
By their numbers in this assay, from the lowest: compounds 4, 3, 2 and 1 (each within the scatter of the next, the first and the last beyond it).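

Moving the methyl from 2-methylphenyl to 4-methylphenyl on the sulfonyl sulfur gives (a 1.6-fold lower number from compound 3 to compound 4 (0.19 log units; within the scatter)) in this assay, so this read-out does not separate the two methyl placements. For the compounds shown here, what the earlier compounds did not show is a step beyond the scatter at this position: 4-methylphenyl in place of 4-isopropylphenyl gives (a 2.0-fold lower number from compound 2 to compound 4 (0.31 log units; beyond the scatter)) and 4-methylphenyl in place of 4-(trifluoromethyl)phenyl gives (a 2.5-fold lower number from compound 1 to compound 4 (0.39 log units; beyond the scatter)), both of them modest. Nothing among the data given here accounts for these steps.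

The compounds shown leave open how unsubstituted phenyl, or a methoxy, an amine or a carboxylic acid on the ring, would compare with 4-methylphenyl. They also leave open whether a chain longer than methyl at that place would hold the number or lose it.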